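A difluorophenyl in place of the methoxyphenyl

The compounds below may be only part of what the source reports. "The series", "measured", "known", "first", "only" and "open" are said of these compounds alone.

Compound 1 `COc1ccc(C(=O)/C=C/c2cc(-c3cc(OC)c(OC)c(OC)c3)n[nH]2)cc1OC` and compound 2 `COc1ccc(C(=O)/C=C/c2cc(-c3cc(OC)c(OC)c(OC)c3)n[nH]2)cc1` share one core and differ by a single methoxy group. In a functional assay on Hs-578T cells (Homo sapiens) for cytotoxicity, read by sulforhodamine B assay, with a stated time of 48 h, tested at 0.01 uM (on this read-out higher numbers stand for a weaker effect at the one concentration tested and lower numbers for a stronger effect), compound 1 gives 98%, and compound 2 gives 99%; the step of a number 1 percentage points higher from compound 1 to compound 2 (within the scatter). The two numbers thus lie within the scatter of each other. Compound 3 `COc1cc(-c2cc(/C=C/C(=O)c3ccc(F)c(F)c3)[nH]n2)cc(OC)c1OC` carries 3,4-difluorophenyl in place of 4-methoxyphenyl on a carbonyl carbon. Within the data shown here, no measured step covers this exchange, and the one change made to this ring left the read-out unchanged. The step of a number 2 percentage points lower from compound 2 to compound 3 (within the scatter) is therefore expected to stay within the scatter. Compound 3 is estimated at 97%, between 85% and 105%.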

Compound 3, a percentage reported as activity, at one concentration (the size of the read-out at that concentration, not a potency): 98%
The estimate for compound 3 lay 1 percentage points below the measured number; measured number inside the range.
By their numbers in this assay, from the lowest: compounds 1, 3 and 2 (each within the scatter of the next).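

In this assay, replacing the whole 4-methoxyphenyl with 3,4-difluorophenyl on the carbonyl carbon gives (a number 1 percentage points lower from compound 2 to compound 3 (within the scatter)), and the comparison with the 3,4-dimethoxyphenyl compound gives (no change at the digits printed from compound 1 to compound 3 (within the scatter)). So the position now shows no step beyond the scatter for an exchange of the ring's substituents for fluorine, not only for the loss of one methoxy. No evidence is available to explain this result. As far as these compounds go, whether an amine or a carboxylic acid on this ring would move the number stays open, as does how these compounds compare at other concentrations.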